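Dropping Both Methoxy Groups From the Urea Aryl Substituent

The compounds below may be only part of what the source reports. "The series", "measured", "known", "first", "only" and "open" are said of these compounds alone.

Measured compounds:
- compound 1, `COc1ccc(OC)c(NC(=O)Nc2nn(-c3ccccc3)c(=O)c3ccccc23)c1`, 0.776 nM
- compound 2, `COc1ccc(NC(=O)Nc2nn(-c3ccccc3)c(=O)c3ccccc23)cc1`, 60.6 nM
- compound 3, `O=C(NCc1ccccc1)Nc1nn(-c2ccccc2)c(=O)c2ccccc12`, 29.6 nM

In an assay on CHO cells for displacement of a labelled ligand from adenosine receptor A3 (Homo sapiens) (on this read-out higher numbers stand for weaker inhibition and lower numbers for stronger inhibition), compound 1 stands lowest of the three numbers. Its nearest neighbour is compound 3, which sits a 38-fold higher number from compound 1 to compound 3 (1.58 log units; beyond the scatter), and the furthest is compound 2, at a 78-fold higher number from compound 1 to compound 2 (1.89 log units; beyond the scatter). Between those two, the change from compound 2 to compound 3 amounts to a 2.0-fold lower number from compound 2 to compound 3 (0.31 log units; beyond the scatter).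

Compound 4, `O=C(Nc1ccccc1)Nc1nn(-c2ccccc2)c(=O)c2ccccc12`, is not yet measured. It differs from compound 1 by phenyl in place of 2,5-dimethoxyphenyl on an amide-type nitrogen. The two measured steps away from compound 1 both bear on this: replacing the 2,5-dimethoxyphenyl by 4-methoxyphenyl or by benzyl each cost a large amount in this assay. A plain phenyl removes both methoxy groups at once, so a step of similar size is expected, giving a higher number than compound 1.

On that basis compound 4 is estimated at 50 nM, within a range from 10 nM to 250 nM, which means an expected step of a 64-fold higher number from compound 1 to compound 4 (1.81 log units; beyond the scatter).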

Compound 4, inhibition constant: 178 nM
Beside the measured number, compound 4's estimate is 3.6-fold (0.55 log units) below it; the measured number falls inside the stated range.
By their numbers in this assay, from the lowest: compound 1; then compound 3; then compound 2; then compound 4.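

Taking away both methoxy groups at once gives the largest step seen at this position, a 230-fold higher number from compound 1 to compound 4 (2.36 log units; beyond the scatter) in this assay, so the full 2,5-dimethoxyphenyl counts for more than either earlier replacement had shown. Within the data shown here, the single remaining methoxy group also matters, since hydrogen in its place on the aromatic carbon gives a 2.9-fold higher number from compound 2 to compound 4 (0.47 log units; beyond the scatter), and a benzyl on the amide-type nitrogen also does better than the plain phenyl, with phenyl in place of benzyl giving a 6.0-fold higher number from compound 3 to compound 4 (0.78 log units; beyond the scatter); of the four groups, phenyl goes with the weakest inhibition. No measurement here accounts for why these groups rank as they do.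

The compounds shown leave open how much each of the two methoxy groups of compound 1 contributes alone, and whether a chlorine atom or an ethoxy group could take the place of either one. They also leave open whether the 2,5-dimethoxy pattern would hold its value on a 2,5-dimethoxybenzyl group, or on a longer chain such as phenethyl.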